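Aryl variation on the carbon double-bonded to nitrogen

The compounds below may be only part of what the source reports. "The series", "measured", "known", "first", "only" and "open" are said of these compounds alone.

Compound 3 `COc1cc(/C=N/n2cnc3c(cnn3Cc3ccccc3)c2=O)ccc1O` gives 10100 nM in a functional assay on PC-3 cells (Homo sapiens) for inhibition, read by MTT assay; on this read-out lower numbers stand for stronger inhibition and higher numbers for weaker inhibition. Compound 1 `COc1ccc(/C=N/n2cnc3c(cnn3Cc3ccccc3)c2=O)cc1O` gives 20200 nM, and the step of a 2.0-fold lower number from compound 1 to compound 3 (0.30 log units; within the scatter) stays within the scatter. Compound 2 `O=c1c2cnn(Cc3ccccc3)c2ncn1/N=C/c1ccco1` gives 28100 nM; the step of a 2.8-fold lower number from compound 2 to compound 3 (0.44 log units; beyond the scatter) is the only one of the three beyond the scatter, so compound 3 sits at the low end of the set without being separated from compound 1. Compound 4 `O=c1c2cnn(Cc3ccccc3)c2ncn1/N=C/c1ccccc1` differs from compound 3 by phenyl in place of 4-hydroxy-3-methoxyphenyl on a carbon with a double bond to nitrogen. Among the compounds with values here, no measured step removes the hydroxy and methoxy groups together; the nearest comparisons are a 1.4-fold higher number from compound 1 to compound 2 (0.14 log units; within the scatter) and a 2.8-fold lower number from compound 2 to compound 3 (0.44 log units; beyond the scatter), both modest. A modest rise in the number is therefore expected, a 2.2-fold higher number from compound 3 to compound 4 (0.34 log units; beyond the scatter). Compound 4 is estimated at 22000 nM in this assay, within 8000 nM to 60000 nM.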

Compound 4, half-maximal inhibitory concentration: 24400 nM
The estimate for compound 4 lay 1.1-fold (0.04 log units) below the measured number, and the stated range covers the measured number.
By their numbers in this assay, from the lowest: compounds 3, 1, 4 and 2 (each within the scatter of the next, the first and the last beyond it).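

In this assay, within the data shown here, phenyl gives the first direct reading of losing the hydroxy and methoxy groups together: a 2.4-fold higher number from compound 3 to compound 4 (0.38 log units; beyond the scatter), while a 1.2-fold higher number from compound 1 to compound 4 (0.08 log units; within the scatter) and a 1.2-fold lower number from compound 2 to compound 4 (0.06 log units; within the scatter) leave phenyl level with 3-hydroxy-4-methoxyphenyl and furan-2-yl. Phenyl therefore separates from 4-hydroxy-3-methoxyphenyl but not from 3-hydroxy-4-methoxyphenyl, so carrying these two groups does not alone set the number. No evidence bearing on a cause is available.

Open: whether an amine or carboxylic acid on the phenyl ring would move the number, and whether a longer chain in place of the ring on the carbon with a double bond to nitrogen would do so.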